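Cytotoxicity notes on oxazolidinone series: compound 3 to compound 4

The source may report more compounds than this note shows. Statements on the series, on what has been measured and on what is new or still open speak of the compounds shown alone.

Measured so far:
compound 1 `O=C1O[C@@H](CO)CN1c1ccc(-n2cc(-c3ccccn3)cn2)c(F)c1` — 59 ug/mL
compound 2 `CCN1CCN(C[C@H]2CN(c3ccc(-n4cc(-c5ccccn5)cn4)c(F)c3)C(=O)O2)CC1` — 99 ug/mL
compound 3 `O=C1O[C@@H](CSc2cccs2)CN1c1ccc(-n2cc(-c3ccccn3)cn2)c(F)c1` — > 400 ug/mL

Values are from an ADME assay on L02 cells (Homo sapiens) for cytotoxicity, read by MTT assay, with a stated time of 48 h; a lower number here means a stronger inhibitor, a higher number a weaker inhibitor. For compound 3 the result is a limit of the assay, not a number (the limit of > 400 ug/mL in this assay, at which 1 of the 3 values shown sits); it is the only one of the three at that limit. Compound 4 `O=C(NC[C@H]1CN(c2ccc(-n3cc(-c4ccccn4)cn3)c(F)c2)C(=O)O1)C(F)F` is not yet measured. The change from compound 3 is ((difluoromethyl)carbonyl)amino in place of (thiophen-2-yl)sulfanyl on a saturated chain carbon bound to a saturated ring carbon. Two measured steps lead into compound 3: an at least 6.7-fold higher number from compound 1 to compound 3 (0.83 log units; beyond the scatter) and an at least 4.0-fold higher number from compound 2 to compound 3 (0.60 log units; beyond the scatter). Both ran toward the limit with the (thiophen-2-yl)sulfanyl group entering; removing it in compound 4 is expected to reverse part of that, so a downward step an at least 3.0-fold lower number from compound 3 to compound 4 (0.48 log units; beyond the scatter) is expected in this assay. Compound 4 is therefore estimated at 130 ug/mL, between 40 ug/mL and 400 ug/mL.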

Compound 4, half-maximal inhibitory concentration: > 400 ug/mL
Compound 4: a limit, no number (the forecaster's own chance of this, stated with the estimate: 25%); at least 3.0-fold (0.48 log units) between middle value and limit.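

In this assay compound 4 gives > 400 ug/mL, a limit of the assay and not a number: the limit of > 400 ug/mL in this assay, at which 2 of the 4 values shown sit.

The step between compound 3 and compound 4 cannot be read, as both are limits. Reaching the limit on a saturated chain carbon bound to a saturated ring carbon therefore does not require the (thiophen-2-yl)sulfanyl group: ((difluoromethyl)carbonyl)amino gives an at least 6.7-fold higher number from compound 1 to compound 4 (0.83 log units; beyond the scatter) and an at least 4.0-fold higher number from compound 2 to compound 4 (0.60 log units; beyond the scatter).

As far as these compounds go, the actual values of compound 3 and compound 4 remain open. Also open, from the compounds shown here alone, is whether a primary amine or a carboxylic acid at this place would stay at the limit or return a measurable number.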